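The source may report more compounds than this note shows. Statements on the series, on what has been measured and on what is new or still open speak of the compounds shown alone.

Compound 1 `CC(=O)Nc1ccc2oc(-c3ccnc(C(=O)N4CC5CC4CN5C(c4ccccc4)c4nnn(C)n4)c3)nc2c1` — in an ADME assay on MDCK cells (Canis lupus familiaris) for cytotoxicity (a lower number here means that less compound is tolerated, a higher number that more compound is tolerated), compound 1 reaches only the assay limit > 50000 nM.
Compound 2 `CC(=O)Nc1ccc2oc(-c3ccnc(C(=O)N4CCN(C(c5nnn(C)n5)c5ccccc5F)CC4)c3)nc2c1` — in this assay compound 2 also reaches only the assay limit > 50000 nM.

Compound 2 therefore stands at the ceiling of what this assay can report, together with every other value shown (the limit of > 50000 nM in this assay, at which 2 of the 2 values shown sit). Among the compounds with values here, no step between two measured compounds is available to guide the next change.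

Compound 3 `CC(=O)Nc1ccc2oc(-c3ccnc(C(=O)N4CCN(C(c5ccc([N+](=O)[O-])cc5)c5nnn(C)n5)CC4)c3)nc2c1` differs from compound 2 in one place: 4-nitrophenyl in place of 2-fluorophenyl on a saturated chain carbon bound to an amine nitrogen in a ring and an aromatic carbon. With both known values sitting at a limit, the step of a number no higher from compound 2 to compound 3 (the limit leaves the size open) in this assay is expected to be none beyond the usual scatter. Compound 3 is accordingly estimated at 50000 nM, within the range 25000 nM to 100000 nM.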

Compound 3, half-maximal cytotoxic concentration: > 50000 nM
Compound 3: a limit, no number (the forecaster's own chance of this, stated with the estimate: 80%); the middle value lies on the limit itself.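

Within the data shown here, no step from compound 2 to compound 3 can be read, because both values are limits and not numbers: the limit of > 50000 nM in this assay, at which 3 of the 3 values shown sit.
The compounds shown leave open whether 4-nitrophenyl and 2-fluorophenyl differ at all in this assay.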